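This account rests on a few compounds, and the source may have more. Where it says the series, first, only, none or still open, it means among the compounds named here.

Compound 1 `Cc1ccc(-c2ccc(C)n2-c2ccc(-c3nc4ccc(F)cc4s3)cc2)cc1` – 16700 nM
Compound 2 `Cc1ccc(-c2ccc(F)cc2)n1-c1ccc(-c2nc3ccc(F)cc3s2)cc1` – 14100 nM
Compound 3 `Cc1ccc(-c2ccc([N+](=O)[O-])cc2)n1-c1ccc(-c2nc3ccc(F)cc3s2)cc1` – 17000 nM

All three numbers come from a functional assay on MDA-MB-231 cells (Homo sapiens) for cytotoxicity, read by MTT assay, with a stated time of 72 h; a lower number here means a stronger inhibitor, a higher number a weaker inhibitor. The three compounds share one core and differ only in the group on the outer phenyl ring. Compound 3 gives the highest of the three numbers, but the gaps are tiny: the step of a 1.0-fold higher number from compound 1 to compound 3 (0.01 log units; within the scatter) and the step of a 1.2-fold higher number from compound 2 to compound 3 (0.08 log units; within the scatter) both lie within the scatter, as does a 1.2-fold lower number from compound 1 to compound 2 (0.07 log units; within the scatter). In short, swapping methyl, fluoro and nitro on that ring left the read-out essentially unchanged.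

Compound 4 `COc1ccc2nc(-c3ccc(-n4c(C)ccc4-c4ccc([N+](=O)[O-])cc4)cc3)sc2c1` is not yet measured. It keeps the nitro of compound 3 and changes the fused ring instead: methoxy in place of fluoro on an aromatic carbon. Going by the values given here, no measured pair alters this position, so the three known steps bear on it only indirectly. They show a core whose read-out barely moved under three different substituent swaps, which gives no reason to expect a large shift here either. The expected step in this assay is therefore none beyond the scatter, a 1.1-fold lower number from compound 3 to compound 4 (0.05 log units; within the scatter), in either direction.

On that basis the estimate for compound 4 in this assay is 15000 nM, with a range from 6000 nM to 40000 nM.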

Compound 4, half-maximal inhibitory concentration: 12700 nM
For compound 4 the middle estimate is 1.2-fold (0.07 log units) above the measured one, within the range that was stated.
By their numbers in this assay, from the lowest: compounds 4, 2, 1 and 3 (each within the scatter of the next).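

Going by these compounds alone, the earlier compounds varied only the group on the outer ring, so compound 4 is the first to test a change on an aromatic carbon of a six-membered aromatic ring of carbon only, part of a fused or bridged system of two rings. In this assay, methoxy in place of fluoro at this position gives a 1.3-fold lower number from compound 3 to compound 4 (0.13 log units; within the scatter), so this change also leaves the read-out without a shift that can be told from ordinary assay noise, even though methoxy has more heavy atoms than fluoro and brings a hydrogen-bond acceptor that fluoro lacks. Nothing else measured here bears on why the read-out stays put at this position.

From the compounds shown here alone, only fluoro and methoxy have been compared at this position, so it remains open whether an amine, a carboxylic acid or a longer chain there would move the number beyond the scatter. Methoxy also appears here only alongside the nitro group of compound 3, which leaves open whether it would act the same way with the methyl of compound 1 or the fluoro of compound 2 on the outer ring.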